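A Nitrile in Place of Fluorine on the Outer Phenyl Ring

A few compounds are considered here, and "the series" means these few. Any claim that something is new, unique, unknown or untested is made for them only; others in the source may bear on it.

Compound 1 `CCOC(=O)c1sc(-c2cccc(NC(=O)c3ccc(C(F)(F)F)cc3)c2)nc1Nc1ccc(N2CCN(C)CC2)cc1` and compound 2 `CCOC(=O)c1sc(-c2cccc(NC(=O)c3ccc(C(C)(C)C)cc3)c2)nc1Nc1ccc(N2CCN(C)CC2)cc1` share a core with compound 3 `CCOC(=O)c1sc(-c2cccc(NC(=O)c3ccccc3F)c2)nc1Nc1ccc(N2CCN(C)CC2)cc1`; in a functional assay on Raji cells (Homo sapiens) for antiproliferative activity, read by CCK-8 assay, with a stated time of 72 h (on this read-out lower numbers stand for stronger inhibition and higher numbers for weaker inhibition), compound 1 stands at "not determined" (no result reported) and compound 2 stands at "not determined" (no result reported), so neither has a result reported. In this assay compound 3 gives 9270 nM; it is the only number shown, so there is nothing to rank it against. Compound 4 `CCOC(=O)c1sc(-c2cccc(NC(=O)c3ccc(C#N)cc3)c2)nc1Nc1ccc(N2CCN(C)CC2)cc1` differs from compound 3 by one exchange: 4-cyanophenyl in place of 2-fluorophenyl on a carbonyl carbon. Among the compounds with values here, no measured pair shows what such an exchange does, so the direction of the step is open. With no guide beyond compound 3 itself, the step is estimated as a 1.1-fold lower number from compound 3 to compound 4 (0.04 log units; within the scatter), which means no change beyond the usual scatter. On that basis compound 4 is expected to give about 8500 nM in this assay, within a range from 3000 nM to 25000 nM.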

Compound 4, half-maximal inhibitory concentration: 14000 nM
Compound 4: middle estimate off by 1.6-fold (0.22 log units), on the low side, within the range that was stated.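

In this assay, within the data shown here, the exchange of 2-fluorophenyl for 4-cyanophenyl on a carbonyl carbon gives a 1.5-fold higher number from compound 3 to compound 4 (0.18 log units; within the scatter), the first step that can be read at this position. The two groups cannot be told apart here, so this change leaves the read-out within its usual scatter. Nothing available explains this result.

The steps to compounds 1 and 2 cannot be read. Also open, as far as these compounds go, is whether the nitrile or its place on the ring counts more, and whether 4-aminophenyl or 4-carboxyphenyl would move the number beyond the scatter.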